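The compounds below may be only part of what the source reports. "The series", "measured", "known", "first", "only" and "open" are said of these compounds alone.

Measured compounds:
compound 1 `O=C1C(O)=C(C(c2ccc([N+](=O)[O-])cc2)c2c[nH]c3ccccc23)C(=O)c2ccccc21` — 60900 nM
compound 2 `Cc1[nH]c2ccccc2c1C(C1=C(O)C(=O)c2ccccc2C1=O)c1ccc([N+](=O)[O-])cc1` — 6000 nM

In a functional assay on ECa-109 cells (Homo sapiens) for cytotoxicity, read by MTT assay, with a stated time of 48 h (a lower number here means a stronger inhibitor, a higher number a weaker inhibitor), compound 2 gives the lowest of the two numbers; compound 1 gives a number that is higher, as the step of a 10-fold lower number from compound 1 to compound 2 (1.01 log units; beyond the scatter) shows. Compound 3 `O=C1C(O)=C(C(c2ccc([N+](=O)[O-])cc2)c2c[nH]c3ccc(Br)cc23)C(=O)c2ccccc21` differs from compound 2 by 5-bromo-1H-indol-3-yl in place of 2-methyl-1H-indol-3-yl on a saturated chain carbon bound to an aromatic carbon and a double-bonded ring carbon. Among the measured compounds shown here, this removes the methyl whose arrival gave the step of a 10-fold lower number from compound 1 to compound 2 (1.01 log units; beyond the scatter), while the bromine has no measured counterpart here. For compound 3 the step of a 5.8-fold higher number from compound 2 to compound 3 (0.77 log units; beyond the scatter) is therefore expected to bring a higher number, reflecting only the loss of the methyl. Compound 3 is estimated at 35000 nM, within 7000 nM to 150000 nM.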

Compound 3, half-maximal inhibitory concentration: 16900 nM
Compound 3: the middle estimate sits 2.1-fold (0.32 log units) above what was measured; low and high end bracket the measured number.
By their numbers in this assay, from the lowest: compound 2; then compound 3; then compound 1.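

In this assay, a bromo in place of hydrogen also helps, with a 3.6-fold lower number from compound 1 to compound 3 (0.56 log units; beyond the scatter), so the number responds to more than the methyl alone. Yet 5-bromo-1H-indol-3-yl does not match 2-methyl-1H-indol-3-yl, as a 2.8-fold higher number from compound 2 to compound 3 (0.45 log units; beyond the scatter) shows, and compound 2 remains the strongest inhibitor of the three. No measurement here explains why either group lowers the number.

Still open, as far as these compounds go, is whether the methyl and the bromo would add up in a single compound. From the compounds shown here alone, it is also open whether a chloro or a methoxy in the bromo's place would act alike.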